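From Compound 1 to Compound 3: An Expected Permeability Step

This account rests on a few compounds, and the source may have more. Where it says the series, first, only, none or still open, it means among the compounds named here.

In an ADME assay on MDCK cells (Canis lupus familiaris) for permeability, in the apical to basolateral direction (on this read-out lower numbers stand for lower permeability and higher numbers for higher permeability), compound 1 `CC(C)[C@@H](c1ccc(-c2ccc3cccc(F)c3c2)[nH]c1=O)[C@H]1OC(=O)NC1=O` gives 9.14 10^-6 cm/s. In this assay compound 2 `CC(C)C(/C=C1\NC(=O)NC1=O)c1ccc(-c2ccc3cccc(F)c3c2)[nH]c1=O` gives 12.3 10^-6 cm/s, and the two numbers lie within the scatter of each other, so neither can be ordered against the other. Compound 3 `CC(C)[C@H](C[C@H]1SC(=O)NC1=O)c1ccc(-c2ccc3cccc(F)c3c2)[nH]c1=O` has not yet been measured. It differs from compound 1 in one place: (2,4-dioxo-1,3-thiazolidin-5-yl)methyl in place of 2,4-dioxo-1,3-oxazolidin-5-yl on a saturated chain carbon bound to an aromatic carbon and a saturated chain carbon. Going by the values given here, no step between measured compounds speaks to this change, so the expectation rests on compound 1 alone. The step of a 1.3-fold higher number from compound 1 to compound 3 (0.12 log units; within the scatter) is expected to be modest and upward, not clearly beyond the scatter. Compound 3 is therefore estimated at 12 10^-6 cm/s, with a range from 6 10^-6 cm/s to 24 10^-6 cm/s.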

Compound 3, apparent permeability: 17.6 10^-6 cm/s
Compound 3: the middle estimate sits 1.5-fold (0.17 log units) below what was measured; measured number inside the range.
By their numbers in this assay, from the lowest: compounds 1, 2 and 3 (each within the scatter of the next).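

In this assay, putting (2,4-dioxo-1,3-thiazolidin-5-yl)methyl in place of 2,4-dioxo-1,3-oxazolidin-5-yl on this saturated chain carbon gives a 1.9-fold higher number from compound 1 to compound 3 (0.28 log units; within the scatter). Going by these compounds alone, this is the first step read at this place, and it shows that this exchange of ring and attachment leaves the read-out within the scatter. No measurement at hand gives a cause for the step.

The step joins two changes, sulfur for the ring oxygen and an added carbon, and the compounds shown do not separate them. As far as these compounds go, how an amine or a carboxylic acid at this place would read also remains open.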